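The compounds below may be only part of what the source reports. "The series", "measured", "known", "first", "only" and "open" are said of these compounds alone.

Of the compounds shown here, three of one shared core have been measured so far. Compound 1 `O=C(Nc1ccc(S(=O)(=O)NC2CCCCC2)c2ccccc12)c1ccccc1` gives 4.4 nM in an assay on L1.2 cells for binding affinity to C-C chemokine receptor type 8 (Homo sapiens); a lower number here means a stronger inhibitor, a higher number a weaker inhibitor. Compound 2 `CCOC(=O)N1CCC(NS(=O)(=O)c2ccc(NC(=O)c3ccccc3)c3ccccc23)CC1` gives 0.17 nM, and the step of a 26-fold lower number from compound 1 to compound 2 (1.41 log units; beyond the scatter) is large. Compound 3 `CCOC(=O)N1CCC(NS(=O)(=O)c2ccc(NCc3ccccc3)c3ccccc23)CC1` gives 45.6 nM; the step of a 270-fold higher number from compound 2 to compound 3 (2.43 log units; beyond the scatter) is the largest seen, and compound 3 therefore stands highest of the three numbers, with compound 1 its nearest neighbour.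

Compound 4 `CCOC(=O)N1CCC(NS(=O)(=O)c2ccc(O)c3ccccc23)CC1` differs from compound 3 in one place: hydroxy in place of benzylamino on an aromatic carbon. Of the measured steps, only the change from compound 2 to compound 3 touches this position, and it showed that what sits on this aromatic carbon can move the number over a wide span. Among the measured compounds shown here, no measured compound carries a hydroxy here, so the direction is not fixed by the data. Since compound 3 already stands at the weak end, the expectation for compound 4 is a modest further rise, a 3.3-fold higher number from compound 3 to compound 4 (0.52 log units; beyond the scatter), with a wide range. Compound 4 is estimated at 150 nM, between 20 nM and 1500 nM.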

Compound 4, inhibition constant: > 5000 nM
Compound 4: no number, only a limit (the forecaster's own chance of this, stated with the estimate: 10%); middle value at least 33-fold (1.52 log units) from the limit.
By their numbers in this assay, from the lowest: compound 2; then compound 1; then compound 3. At a limit, above all of these: compound 4.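

In this assay the reading for compound 4 is a limit and not a number: the limit of > 5000 nM in this assay, at which 1 of the 4 values shown sits. Among the compounds shown here, the earlier compounds compared only two nitrogen-linked groups on this aromatic carbon, each carrying a six-membered aromatic ring. As far as these compounds go, replacing the whole group with hydroxy goes further, giving an at least 100-fold higher number from compound 3 to compound 4 (2.04 log units; beyond the scatter) and, against the benzamido compound, an at least 29000-fold higher number from compound 2 to compound 4 (4.46 log units; beyond the scatter), so both steps are large even though their true size stays unknown. Benzylamino and hydroxy have the same counted hydrogen-bond donors and acceptors, so those counts do not separate compound 3 from compound 4, whereas the ring and the other heavy atoms that leave do differ.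

The compounds shown leave open whether the linking nitrogen or the aromatic ring carries more weight here. A plain amine or an acetamide on this carbon would separate the two.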